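The source may hold more compounds than are shown below. What is called first, only, known or untested is meant among the compounds shown, and "the series" means these compounds.

Measured in a functional assay on SMMC-7721 cells (Homo sapiens) for cytotoxicity, read by MTT assay, with a stated time of 72 h; a lower number here means a stronger inhibitor, a higher number a weaker inhibitor:
- compound 1 `O=C1C(=Cc2ccc(F)cc2)C(=O)N(c2ccc(Cl)cc2)N1c1ccc(Cl)cc1`: 23300 nM
- compound 2 `COc1cccc(C=C2C(=O)N(c3ccc(Cl)cc3)N(c3ccc(Cl)cc3)C2=O)c1`: 30200 nM
- compound 3 `COc1ccc(C=C2C(=O)N(c3ccc(Cl)cc3)N(c3ccc(Cl)cc3)C2=O)cc1OC`: > 128000 nM

The entry for compound 3 is a limit of the assay and not a number.

Compound 4 `COc1ccccc1C=C1C(=O)N(c2ccc(Cl)cc2)N(c2ccc(Cl)cc2)C1=O` has 2-methoxyphenyl in place of 3,4-dimethoxyphenyl on a double-bonded chain carbon bound to a double-bonded ring carbon.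

Going by the values given here, the steps that bear on this are an at least 4.2-fold higher number from compound 2 to compound 3 (0.62 log units; beyond the scatter) and an at least 5.4-fold higher number from compound 1 to compound 3 (0.73 log units; beyond the scatter). A third step, a 1.3-fold higher number from compound 1 to compound 2 (0.11 log units; within the scatter), separates the two compounds with numeric values. Among the compounds with values here, no measured compound carries 2-methoxyphenyl, so the comparison is indirect. With a single methoxy, compound 4 is expected to fall near compound 2, at 30200 nM. A lower number is therefore expected in this assay, with an estimated step of an at least 3.6-fold lower number from compound 3 to compound 4 (0.56 log units; beyond the scatter). For compound 4 the estimate is 35000 nM, expected between 13000 nM and 100000 nM.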

Compound 4, half-maximal inhibitory concentration: 25800 nM
Beside the measured number, compound 4's estimate is 1.4-fold (0.13 log units) above it, within the range that was stated.
By their numbers in this assay, from the lowest: compounds 1, 4 and 2 (each within the scatter of the next). At a limit, above all of these: compound 3.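

In this assay, the 2-methoxyphenyl group of compound 4 is not told apart from the 3-methoxyphenyl group, at a 1.2-fold lower number from compound 2 to compound 4 (0.07 log units; within the scatter), or from the 4-fluorophenyl group, at a 1.1-fold higher number from compound 1 to compound 4 (0.04 log units; within the scatter). On the double-bonded chain carbon, only 3,4-dimethoxyphenyl stands apart so far, with an at least 4.9-fold lower number from compound 3 to compound 4 (0.69 log units; beyond the scatter). The entry for compound 3 is a limit and not a number: the limit of > 128000 nM in this assay, at which 1 of the 4 values shown sits.

Going by these compounds, the true size of that step stays open. So does what a 4-methoxyphenyl group or an aminophenyl group would give at this place.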